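Trimethoxyphenyl in place of phenyl: expectation for compound 4

The source may report more compounds than this note shows. Statements on the series, on what has been measured and on what is new or still open speak of the compounds shown alone.

Measured so far in an ADME assay on CCRF-CEM cells (Homo sapiens) for inhibition, read by cell counting; on this read-out lower numbers stand for stronger inhibition and higher numbers for weaker inhibition:
compound 1 `CSc1nc(NCCCNc2ccnc3cc(Cl)ccc23)c(C#N)c(-c2ccccc2)n1`: 4700 nM
compound 2 `CSc1nc(NCCCCNc2ccnc3cc(Cl)ccc23)c(C#N)c(-c2ccccc2)n1`: 5200 nM
compound 3 `COc1ccc(-c2nc(SC)nc(NCCCCNc3ccnc4cc(Cl)ccc34)c2C#N)cc1`: 2700 nM

Compound 2 stands highest of the three numbers in this assay, yet neither compound 1 nor compound 3 is separated from it beyond the usual scatter. For the measured compounds named here, the only single-point step among the measured compounds is the one from compound 2 to compound 3, methoxy in place of hydrogen on an aromatic carbon, which gave a 1.9-fold lower number from compound 2 to compound 3 (0.28 log units; within the scatter).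

Compound 4 `COc1cc(-c2nc(SC)nc(NCCCCNc3ccnc4cc(Cl)ccc34)c2C#N)cc(OC)c1OC` has not been measured. It differs from compound 2 in one place: 3,4,5-trimethoxyphenyl in place of phenyl on an aromatic carbon. This change contains the methoxy step already seen, and adds two further methoxy groups on the same ring. The step from compound 2 to compound 3 is the only measured one that bears on it, and it stayed within the scatter. Going by the values given here, no step to a larger change of this kind has been measured, so nothing here supports more than a modest shift.

On that basis compound 4 is expected to come in somewhat lower than compound 2, roughly a 1.7-fold lower number from compound 2 to compound 4 (0.24 log units; within the scatter), with the move quite possibly again within the scatter. The estimate for compound 4 in this assay is 3000 nM, in the range 1200 nM to 7500 nM.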

Compound 4, half-maximal inhibitory concentration: 3600 nM
Beside the measured number, compound 4's estimate is 1.2-fold (0.08 log units) below it; measured number inside the range.
By their numbers in this assay, from the lowest: compounds 3, 4, 1 and 2 (each within the scatter of the next).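

At this position, on the aromatic carbon next to the ring nitrogen and ortho to a cyano group, enlarging phenyl (6 heavy atoms) to 3,4,5-trimethoxyphenyl (12 heavy atoms) gives a 1.4-fold lower number from compound 2 to compound 4 (0.16 log units; within the scatter) in this assay, so even this larger change leaves the read-out within the scatter. For the compounds shown here, the two further methoxy groups that separate 3,4,5-trimethoxyphenyl from 4-methoxyphenyl give a 1.3-fold higher number from compound 3 to compound 4 (0.12 log units; within the scatter), so the series so far shows no separation in this assay between the unsubstituted ring, the single methoxy group and the three methoxy groups, and no trend with the number of methoxy groups can be read from these compounds. No available evidence bears on this result.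

Open, on these data alone, is whether any group at this position moves the number beyond the scatter, for example a carboxylic acid or a dimethylamino group on the phenyl ring, or a saturated amine such as morpholine in place of the phenyl ring. Also open, as far as these compounds go, is whether 3,4,5-trimethoxyphenyl gives a similar result on the chain of compound 1 or on a longer chain.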